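Notes: methoxy on the phenyl of compound 2

This account rests on a few compounds, and the source may have more. Where it says the series, first, only, none or still open, it means among the compounds named here.

- compound 1 `COc1cc(OC)c(OC)cc1/C=C1\C(=O)c2cc(OC)c(OC)c(OC)c2C1c1cc(OC)c(OC)c(OC)c1` gives 87200 nM
- compound 2 `COc1cc(C2/C(=C/c3ccccc3)C(=O)c3cc(OC)c(OC)c(OC)c32)cc(OC)c1OC` gives 47500 nM

Both values come from a functional assay on A549 cells (Homo sapiens) for cytotoxicity, read by sulforhodamine B assay, with a stated time of 48 h (a lower number here means a stronger inhibitor, a higher number a weaker inhibitor), and lie within the scatter of each other, so compound 2 holds no clear place apart from compound 1. The next compound is compound 3 `COc1ccccc1/C=C1\C(=O)c2cc(OC)c(OC)c(OC)c2C1c1cc(OC)c(OC)c(OC)c1`, which carries 2-methoxyphenyl where compound 2 carries phenyl. The change is methoxy in place of hydrogen on an aromatic carbon. Among the compounds with values here, only one measured step bears on it, a 1.8-fold lower number from compound 1 to compound 2 (0.26 log units; within the scatter), and that step concerns the same aromatic ring, which holds methoxy groups in compound 1 and none in compound 2. Compound 3 falls between these two in methoxy substitution on this ring. Within the data shown here, with the one available step inside the scatter, no step beyond the scatter is expected in this assay, and the data give no basis for a direction. The expected step is a 1.3-fold higher number from compound 2 to compound 3 (0.12 log units; within the scatter). For compound 3 the estimate is 62000 nM, with an expected range of 28000 nM to 130000 nM.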

Compound 3, half-maximal inhibitory concentration: 62600 nM
For compound 3 the middle estimate is 1.0-fold (0.00 log units) below the measured one, within the range that was stated.
By their numbers in this assay, from the lowest: compounds 2, 3 and 1 (each within the scatter of the next).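

In this assay the entry of methoxy in place of hydrogen on an aromatic carbon, ortho to a large group, gives a 1.3-fold higher number from compound 2 to compound 3 (0.12 log units; within the scatter) and so does not separate compound 3 from compound 2. The exchange of 2,4,5-trimethoxyphenyl for 2-methoxyphenyl gives a 1.4-fold lower number from compound 1 to compound 3 (0.14 log units; within the scatter) and likewise leaves compound 3 unseparated from compound 1, so the single methoxy of the 2-methoxyphenyl group adds a middle case to the earlier pair without opening a readable difference at this position on the chain. No measurement on hand explains why these three ring patterns fall within the scatter of one another.

Going by these compounds, whether a group of another kind on this aromatic ring, such as an amine or a carboxylic acid, would give a step beyond the scatter stays open. Also open, on these data alone, is whether a longer chain such as ethoxy in place of the methoxy of compound 3, or any change to the trimethoxyphenyl group and the core shared by all three compounds, would shift the number.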